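Swapping pyrrolidin-1-yl for 4-methylpiperazin-1-yl

A few compounds are considered here, and "the series" means these few. Any claim that something is new, unique, unknown or untested is made for them only; others in the source may bear on it.

- Compound 1 `CCN(CC)CC(O)Cn1cc(CC(=O)O)c2ccccc21`: 6630 nM
- Compound 2 `O=C(O)Cc1cn(CC(O)CN2CCCC2)c2ccccc12`: 720 nM

Within the data shown here, in a functional assay on HeLa cells (Homo sapiens) for inhibition, read by MTT assay, with a stated time of 72 h (a lower number here means a stronger inhibitor, a higher number a weaker inhibitor), compound 2 gives 720 nM, the lower of the two numbers so far, which makes it the stronger inhibitor of the pair. Compound 3 `CN1CCN(CC(O)Cn2cc(CC(=O)O)c3ccccc32)CC1` has yet to be measured. It carries 4-methylpiperazin-1-yl in place of pyrrolidin-1-yl on a saturated chain carbon, two bonds along the chain from an oxygen on a saturated carbon.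

Among the measured compounds shown here, only one measured step bears on this place: a 9.2-fold lower number from compound 1 to compound 2 (0.96 log units; beyond the scatter), a modest change that lies beyond the scatter. It shows that exchanging the group here can move the number clearly, but it says nothing directly about the incoming group. Compound 2 already holds the better value, while compound 1 at 6630 nM shows that another group at this place can sit much higher. A step of modest size towards a higher number in this assay is therefore expected, and it should be smaller than the measured one. The expected change is a 2.8-fold higher number from compound 2 to compound 3 (0.44 log units; beyond the scatter). For compound 3 the estimated value is 2000 nM, with an expected range from 500 nM to 8000 nM.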

Compound 3, half-maximal inhibitory concentration: 3970 nM
The estimate for compound 3 lay 2.0-fold (0.30 log units) below the measured number, within the range that was stated.
By their numbers in this assay, from the lowest: compound 2; then compounds 3 and 1 (each within the scatter of the next).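

In this assay, the move from a five-membered ring to a six-membered ring with a second nitrogen does not keep the low number of compound 2: the change gives a 5.5-fold higher number from compound 2 to compound 3 (0.74 log units; beyond the scatter). Set against the open-chain diethylamino group, 4-methylpiperazin-1-yl gives a 1.7-fold lower number from compound 1 to compound 3 (0.22 log units; within the scatter), so compound 1 and compound 3 cannot be told apart here, and among these three amines only the pyrrolidin-1-yl group of compound 2 stands clear of the other two. Nothing on hand accounts for this order among the groups.

The compounds shown do not separate the contributions of ring size, the second ring nitrogen and its methyl group, since 4-methylpiperazin-1-yl differs from pyrrolidin-1-yl in all three at once; piperidin-1-yl, morpholin-4-yl and unsubstituted piperazin-1-yl would pull these apart. Going by these compounds, it also stays open whether the advantage of pyrrolidin-1-yl would hold if the carboxylic acid of the shared core gave way to a methyl ester or a primary amide, or if the hydroxyl group on the chain were removed.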